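The source may hold more compounds than are shown below. What is called first, only, known or untested is meant among the compounds shown, and "the series" means these compounds.

Compound 1 `CN(C)c1c(C#N)c2c(N)ncnc2n1C` is one of two compounds with numbers in an assay on isolated protein for binding affinity to Leucine-rich repeat serine/threonine-protein kinase 2 variant G2019S (Homo sapiens), read by TR-FRET and LanthaScreen, with a stated time of 2 h; on this read-out higher numbers stand for weaker inhibition and lower numbers for stronger inhibition. In this assay compound 1 gives 259 nM, the lower of the two numbers. For the measured compounds named here, the other, compound 2 `C[C@@H]1CCCN1c1c(C#N)c2c(N)nc(Nc3cnn(C)c3)cc2n1C`, gives 794 nM in this assay, a value that lies beyond the scatter above that of compound 1; compound 2 differs from compound 1 in more than one place, so the two values show only that compound 2 sits higher, not which change is responsible.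

The next compound, compound 3 `C[C@H]1CCCN1c1c(C#N)c2c(N)ncnc2n1C`, keeps the core of compound 1 and changes one group: 2-methylpyrrolidin-1-yl in place of dimethylamino on an aromatic carbon. Going by the values given here, compound 2 already carries a 2-methylpyrrolidin-1-yl group, on the opposite stereocentre, with a second change elsewhere, so the data hold no step that isolates this exchange.

With compound 1 at 259 nM as the only anchor, the step from compound 1 to compound 3 is expected to be small, a 1.2-fold higher number from compound 1 to compound 3 (0.09 log units; within the scatter), within or only slightly beyond the scatter. Compound 3 is therefore estimated at 320 nM in this assay, with a range from 100 nM to 1000 nM.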

Compound 3, inhibition constant: 212 nM
Estimate against measurement, compound 3: 1.5-fold (0.18 log units) above; the range from low to high includes it.
By their numbers in this assay, from the lowest: compounds 3 and 1 (each within the scatter of the next); then compound 2.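

On the core of compound 1, placing 2-methylpyrrolidin-1-yl instead of dimethylamino on the aromatic carbon of the five-membered ring gives a 1.2-fold lower number from compound 1 to compound 3 (0.09 log units; within the scatter) in this assay, so this read-out does not separate the two groups at this position. For the compounds shown here, this is the first step that isolates a single place, since the only earlier pair differed in more than one place and could not be tied to any one change. Within this one pair, the position carries an amine with a five-membered non-aromatic ring and a defined stereocentre, in place of an open dimethylamino group, and the number stays within the scatter.

No supporting measurement bears on why the two values lie so close together.
Going by these compounds, how the opposite stereocentre of 2-methylpyrrolidin-1-yl would read on the core of compound 1 remains open, as does whether the same holds for a larger ring amine such as piperidine or morpholine, or for a longer chain such as diethylamino at this position.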